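Chain shortening to sulfo: stability across two cores

The source may report more compounds than this note shows. Statements on the series, on what has been measured and on what is new or still open speak of the compounds shown alone.

In a physicochemical assay for metabolic stability, at 40 degrees C (on this read-out lower numbers stand for a shorter-lived compound and higher numbers for a longer-lived compound), compound 1 `CC1(C)C(=O)N(CCCS(=O)(=O)O)C(=O)N1Cl` reaches only a limit of the assay, > 336 h. Compound 3 `CC1(C)C(=O)N(CCS(=O)(=O)O)C(=O)N1Cl` gives 1560 h in this assay. The change between them is sulfo in place of sulfomethyl on a saturated chain carbon, two bonds along the chain from an amide-type nitrogen in a ring; the step that the limit leaves unreadable from compound 1 to compound 3 cannot be sized, since compound 1 sits at the limit of > 336 h in this assay, at which 1 of the 3 values shown sits.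

Compound 2 `CC1(C)C(=O)N(CCCCS(=O)(=O)O)C(C)(C)N1Cl` also returns only a limit in this assay, > 2010 h, and so stands at the limit of > 2010 h in this assay, at which 1 of the 3 values shown sits. How the core of compound 2 differs from the core of compound 1 is not broken down here.

Compound 4 `CC1(C)C(=O)N(CCCS(=O)(=O)O)C(C)(C)N1Cl` is not yet measured in this assay. It differs from compound 2 by sulfo in place of sulfomethyl on a saturated chain carbon, three bonds along the chain from an amide-type nitrogen in a ring. This is the same kind of change as that from compound 1 to compound 3, but the place is not the same: there the sulfomethyl sat on a saturated chain carbon two bonds along the chain from an amide-type nitrogen in a ring, here three bonds along that chain.

Since the measured step of this kind is unreadable, no direction can be taken from it. The expectation rests on compound 3 reaching 1560 h after the same kind of change. It also rests on compound 2 already standing at a limit of the assay. The expected step is a number no higher from compound 2 to compound 4 (the limit leaves the size open) in this assay. Compound 4 is estimated at 2000 h, with a range from 700 h to 5000 h, and a fair chance that only a limit is reported.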

Compound 4, half-life: > 5970 h
Compound 4 gave a limit, no number; the forecaster's own chance of this, stated with the estimate: 50%; middle value at least 2.9-fold (0.47 log units) away from the limit.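

In this assay compound 4 returns only a limit, > 5970 h, and compound 2 also stands at a limit, so no step can be read between compound 2 and compound 4. The compounds shown leave open whether sulfo in place of sulfomethyl shifts the half-life at all, in which direction and by how much, on either core.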